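The source may report more compounds than this note shows. Statements on the series, on what has been measured and on what is new or still open speak of the compounds shown alone.

Measured so far in an ADME assay on Huh-7 cells (Homo sapiens) for cytotoxicity; on this read-out lower numbers stand for higher toxicity in this test and higher numbers for lower toxicity in this test:

Compound 1 `N#Cc1cccc(C(=O)NC(=S)N2CCc3c(OCCCCCOc4ccc(Cl)cc4)cccc32)c1` gives 9750 nM.
Compound 2 `O=C(NC(=S)N1CCc2c(OCCCCCOc3ccc(Cl)cc3)cccc21)C1CCCC1` reaches only the limit > 50000 nM.
Compound 3 `O=C(NC(=S)N1CCc2c(OCCCCCOc3ccc(Cl)cc3)cccc21)c1ccsc1` likewise sits at the limit > 50000 nM.

Among the compounds with values here, compound 1 thus holds the only value that is a plain number; the other two are limits of this assay, a fact summed up as the limit of > 50000 nM in this assay, at which 2 of the 3 values shown sit. Compound 4 `O=C(NC(=S)N1CCc2c(OCCCCCOc3ccc(Cl)cc3)cccc21)c1cc2ccccc2s1` has not yet been measured. It differs from compound 1 by 1-benzothiophen-2-yl in place of 3-cyanophenyl on a carbonyl carbon. Both measured steps away from the 3-cyanophenyl went the same way: an at least 5.1-fold higher number from compound 1 to compound 2 (0.70 log units; beyond the scatter) and an at least 5.1-fold higher number from compound 1 to compound 3 (0.70 log units; beyond the scatter). The step from compound 2 to compound 3 cannot be read, since both are limits. A comparable upward step is therefore expected for compound 4, a 4.6-fold higher number from compound 1 to compound 4 (0.66 log units; beyond the scatter). Compound 4 is estimated at 45000 nM, within a range from 12000 nM to 100000 nM.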

Compound 4, half-maximal cytotoxic concentration: > 50000 nM
Compound 4: only a limit was reported; the forecaster's own chance of this, stated with the estimate: 55%; middle value at least 1.1-fold (0.04 log units) away from the limit.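

In this assay, moving away from the 3-cyanophenyl on the carbonyl carbon also raises the number when 1-benzothiophen-2-yl enters, giving an at least 5.1-fold higher number from compound 1 to compound 4 (0.70 log units; beyond the scatter). Cyclopentyl, thiophen-3-yl and 1-benzothiophen-2-yl all go the same way, and none of the compounds shown goes against this. The steps among compounds 2, 3 and 4 cannot be read, because all three values are limits: the limit of > 50000 nM in this assay, at which 3 of the 4 values shown sit.

The compounds shown leave open whether the nitrile or the phenyl ring carrying it sets compound 1 apart. An unsubstituted phenyl on the same carbonyl carbon would separate the two.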